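Swapping hydroxy for carbamoyl: a solubility estimate

This account rests on a few compounds, and the source may have more. Where it says the series, first, only, none or still open, it means among the compounds named here.

Measured in a physicochemical assay for solubility, in phosphate buffer, at pH 7.4; on this read-out lower numbers stand for lower solubility and higher numbers for higher solubility:
- Compound 1 `OCC1CCN(c2nccnc2OC2CN(c3nc4ccccc4s3)C2)CC1`: 31000 nM
- Compound 2 `OCC1CCN(c2nccnc2OC2CN(c3ncc4ccccc4n3)C2)CC1`: 174000 nM
- Compound 3 `OC1CCN(c2nccnc2OC2CN(c3ccc4ccccc4n3)C2)CC1`: 99000 nM

Repeated measurements of one compound never agree exactly, so small gaps between values carry little meaning. Compound 3 and compound 2 lie within that usual scatter of each other, and together they form the upper part of this small set. Compound 1 lies beyond the scatter on the low side of compound 3.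

The unmeasured compound 4 `NC(=O)C1CCN(c2nccnc2OC2CN(c3ccc4ccccc4n3)C2)CC1` keeps all of compound 3 except one group. 4-Hydroxypiperidin-1-yl becomes 4-carbamoylpiperidin-1-yl, which means carbamoyl in place of hydroxy on a saturated ring carbon.

Among the measured compounds shown here, no two measured compounds differ in one place only, so these data contain no direct measure of such a swap. The expectation therefore starts from compound 3 at 99000 nM, with a wide margin, and foresees no step beyond the scatter in this assay. The expected step is small and slightly downward, a 1.2-fold lower number from compound 3 to compound 4 (0.09 log units; within the scatter). The estimated value for compound 4 is 80000 nM, expected to fall between 25000 nM and 200000 nM.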

Compound 4, solubility: 14000 nM
Compound 4: middle estimate off by 5.7-fold (0.76 log units), on the high side; measured number below the stated range.
By their numbers in this assay, from the lowest: compound 4; then compound 1; then compounds 3 and 2 (each within the scatter of the next).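

In this assay, among the compounds shown here, the change from 4-hydroxypiperidin-1-yl to 4-carbamoylpiperidin-1-yl gives a 7.1-fold lower number from compound 3 to compound 4 (0.85 log units; beyond the scatter), the first comparison in this set in which only one place differs, and it shows that this saturated ring carbon, three ring bonds from the ring nitrogen, is not indifferent to the group it carries. The leaving and entering groups have the same tally of hydrogen-bond donors and acceptors and neither carries a net charge, so matching those counts did not keep the number in place; what differs in the count is the heavy atoms and the double bond of the carbamoyl group. No measurement here bears on why the number moves.

From the compounds shown here alone, it remains open whether other groups on this carbon, such as an amine, a carboxylic acid or a methyl ester, would give a step as large as this one or a much smaller one. A single pair also cannot tell whether the same swap would have a similar size on another core, such as the core of compound 1.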